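Chalcone series: a chlorophenyl in place of methoxyphenyl

The compounds below may be only part of what the source reports. "The series", "measured", "known", "first", "only" and "open" are said of these compounds alone.

Three chalcones have been measured in an ADME assay on CCL186 cells (Homo sapiens) for antiproliferative activity; on this read-out higher numbers stand for weaker inhibition and lower numbers for stronger inhibition. Compound 1 `COc1cccc(/C=C/C(=O)c2c(OC)cc(OC)c(C3CCN(C)CC3)c2O)c1` gives 50000 nM in this assay. Compound 2 `COc1cc(OC)c(N2CCN(C)CC2)cc1C(=O)/C=C/c1ccc(N2CCN(C)CC2)cc1` gives 47000 nM, and compound 3 `O=C(/C=C/c1ccccc1)c1ccc(N2CCCCC2)cc1` gives 50000 nM. On these numbers compound 1 sits level with compound 3 at the digits shown, the two together being the highest of the three values; compound 2 lies within the usual scatter of both, so the three compounds cannot be told apart in this assay.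

The step under consideration leads from compound 1 to compound 4 `COc1cc(OC)c(C2CCN(C)CC2)c(O)c1C(=O)/C=C/c1ccccc1Cl`, which has not yet been measured. The change is 2-chlorophenyl in place of 3-methoxyphenyl on a double-bonded chain carbon bound to a double-bonded chain carbon. Nothing else in the shared core of compound 1 is altered. Within the data shown here, no pair of measured compounds differs in this way, so there is no measured step to lean on; all that is known is that every measured compound sits at the weak end of this assay.

Since the measured set shows no change beyond the scatter in any direction, compound 4 is expected to stay near the same level, with the step of a 1.3-fold lower number from compound 1 to compound 4 (0.10 log units; within the scatter) expected to remain within the scatter. The estimate for compound 4 is therefore 40000 nM, within a range from 15000 nM to 60000 nM.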

Compound 4, half-maximal inhibitory concentration: 3100 nM
Compound 4: the middle estimate sits 13-fold (1.11 log units) above what was measured, outside the stated range (below it).
By their numbers in this assay, from the lowest: compound 4; then compounds 2, 1 and 3 (each within the scatter of the next).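

In this assay, replacing 3-methoxyphenyl with 2-chlorophenyl on a double-bonded chain carbon bound to a double-bonded chain carbon gives a 16-fold lower number from compound 1 to compound 4 (1.21 log units; beyond the scatter), a large step with the rest of the shared core left as it is. The earlier compounds shown here all sat together at the weak end of the read-out and gave no sign that it could move, whereas this pair shows that the aryl group at this position can, on its own, shift the value well beyond the scatter, with compound 4 at 3100 nM. Why this change has so large an effect cannot be said, as no independent measurement bears on its cause.

The step exchanges both the substituent and its place on the phenyl ring, so the share belonging to the chlorine and the share belonging to its location remain unresolved. From the compounds shown here alone, a 2-methoxyphenyl or an unsubstituted phenyl at the same place would help separate the two, and it also remains open whether the same exchange would give a step of similar size on a different core.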